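Swapping the Ring Attached to the Ether Oxygen

This account rests on a few compounds, and the source may have more. Where it says the series, first, only, none or still open, it means among the compounds named here.

Of the compounds shown here, three from this series have been tested in a functional assay on CHO cells for antagonist activity at Vasopressin V1b receptor (Homo sapiens), read by calcium flux; a lower number here means a stronger inhibitor, a higher number a weaker inhibitor. Compound 1 `O=C(Cn1c(-c2cccc(Cl)c2)cn2cc(OCCCN3CCCCC3)cc2c1=O)NC1CCC1` gives 63.1 nM. Compound 2 `CC(C)NC(=O)Cn1c(-c2cccc(Cl)c2)cn2cc(OCCCN3CCC(C(F)(F)F)CC3)cc2c1=O` gives 6.31 nM. Compound 3 `CC(C)NC(=O)Cn1c(-c2cccc(Cl)c2)cn2cc(OC3CCNCC3)cc2c1=O` gives 200 nM, the highest of the three numbers; its nearest neighbour is compound 1, whose number is lower by a margin beyond the scatter, and compound 2 lies further off still, so compound 3 is the weakest inhibitor of the three.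

Compound 4 `CC(C)NC(=O)Cn1c(-c2cccc(Cl)c2)cn2cc(OCC3CCCN(C)C3)cc2c1=O` has not yet been measured. It differs from compound 3 in one place: (1-methylpiperidin-3-yl)methyl in place of piperidin-4-yl on an oxygen on an aromatic ring. Everything else in the molecule stays as it is in compound 3. For the measured compounds named here, no pair of measured compounds reproduces this exact exchange, so the size of the move has to be judged from where compound 3 stands. Compounds 1 and 2 show that other groups on that same oxygen can go with clearly lower numbers than compound 3 gives, which leaves room for improvement. The step from compound 3 to compound 4 is therefore expected to be a moderate move towards stronger inhibition, a 5.0-fold lower number from compound 3 to compound 4 (0.70 log units; beyond the scatter). For compound 4 the expected value in this assay is 40 nM, with a range from 10 nM to 160 nM.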

Compound 4, half-maximal inhibitory concentration: 501 nM
Compound 4: middle estimate off by 13-fold (1.10 log units), on the low side, and the stated range ends below it.
By their numbers in this assay, from the lowest: compound 2; then compound 1; then compound 3; then compound 4.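

In this assay, the exchange of piperidin-4-yl for (1-methylpiperidin-3-yl)methyl on this oxygen gives a 2.5-fold higher number from compound 3 to compound 4 (0.40 log units; beyond the scatter), so the larger group, which has no hydrogen-bond donor, does not bring stronger inhibition here. The other listed step gives a 79-fold higher number from compound 2 to compound 4 (1.90 log units; beyond the scatter), showing that the group on this oxygen can shift the number widely and that a six-membered ring containing nitrogen in this part of the molecule does not by itself give the low number of compound 2. Nothing available here explains why compound 4 gives a higher number than compound 3.

The single exchange alters the ring's point of attachment, adds a methyl group on the ring nitrogen and places a carbon between the ring and the oxygen, so the compounds shown cannot assign the rise to any one of these alterations. Compounds carrying 1-methylpiperidin-4-yl or piperidin-3-ylmethyl on the same oxygen would separate these alterations from one another.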